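The source may report more compounds than this note shows. Statements on the series, on what has been measured and on what is new or still open speak of the compounds shown alone.

Measured compounds in an assay on isolated protein for inhibition of Myeloperoxidase (Homo sapiens), read by fluorescence, with stated times of 10 min, 30 s and 5 min; on this read-out lower numbers stand for stronger inhibition and higher numbers for weaker inhibition:
compound 1 `Nc1nc(OCc2ccc(F)cc2)c2nn[nH]c2n1` gives 47 nM
compound 2 `Nc1nc(OCc2ccc(C(F)(F)F)cc2)c2nn[nH]c2n1` gives 140 nM

Compound 2 has the highest of the two numbers in this assay ; the nearest is compound 1, separated by a 3.0-fold higher number from compound 1 to compound 2 (0.47 log units; beyond the scatter). Compound 3 `Cc1ccc(COc2nc(N)nc3[nH]nnc23)cc1` differs from compound 2 by methyl in place of trifluoromethyl on an aromatic carbon. Going by the values given here, the only step that bears on this change is a 3.0-fold higher number from compound 1 to compound 2 (0.47 log units; beyond the scatter), where the smaller fluoro gave the lower number. Returning to a small group at the same position is therefore expected to give a modest lowering, and compound 3 is estimated at 65 nM (range 25 nM to 170 nM), a step of a 2.2-fold lower number from compound 2 to compound 3 (0.33 log units; beyond the scatter) expected.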

Compound 3, half-maximal inhibitory concentration: 510 nM
Estimate against measurement, compound 3: 7.8-fold (0.89 log units) below, outside the stated range (above it).
By their numbers in this assay, from the lowest: compound 1; then compound 2; then compound 3.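

Methyl in place of trifluoromethyl gives a 3.6-fold higher number from compound 2 to compound 3 (0.56 log units; beyond the scatter) and so raises the number, even though the entering group is the smaller of the two by heavy atoms. Methyl in place of fluoro gives an 11-fold higher number from compound 1 to compound 3 (1.04 log units; beyond the scatter) as the largest step of the three, so heavy-atom count alone does not order this position, para to a large group. Nothing at hand accounts for this order.

Open, as far as these compounds go, is where chloro, methoxy or an amine at this place would fall relative to the two fluorine-bearing groups and methyl. Also open, from the compounds shown here alone, is whether plain hydrogen there would sit nearer compound 1 or compound 3.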